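Working notes: from compound 3 to compound 4

A few compounds are considered here, and "the series" means these few. Any claim that something is new, unique, unknown or untested is made for them only; others in the source may bear on it.

In a functional assay on Jurkat cells (Homo sapiens) (on this read-out lower numbers stand for stronger inhibition and higher numbers for weaker inhibition), compound 3 `C[C@H](NC(=O)C(=O)NCc1ccccc1F)C(=O)N[C@@H](CC(=O)O)C(=O)COc1c(F)c(F)cc(F)c1F` gives 207 nM and compound 2 `Cc1cccc(CNC(=O)C(=O)N[C@@H](C)C(=O)N[C@@H](CC(=O)O)C(=O)COc2c(F)c(F)cc(F)c2F)c1` gives 127 nM, so the two stand together at the weak end of the series, while compound 1 `C[C@H](NC(=O)C(=O)NCC1CCCCC1)C(=O)N[C@@H](CC(=O)O)C(=O)COc1c(F)c(F)cc(F)c1F` gives 19 nM. Compound 4 `C[C@H](NC(=O)C(=O)NCc1ccc(Cl)cc1Cl)C(=O)N[C@@H](CC(=O)O)C(=O)COc1c(F)c(F)cc(F)c1F` has 2,4-dichlorophenyl in place of 2-fluorophenyl on a saturated chain carbon bound to an amide-type nitrogen. Among the compounds with values here, the closest precedent, one substituted phenyl for another, is a 1.6-fold higher number from compound 2 to compound 3 (0.21 log units; within the scatter), which stays within the scatter. The large steps, a 6.7-fold higher number from compound 1 to compound 2 (0.83 log units; beyond the scatter) and an 11-fold higher number from compound 1 to compound 3 (1.04 log units; beyond the scatter), both leave cyclohexyl, so they bear less directly. Within the data shown here, no measured compound carries chlorine. No step beyond the scatter is therefore expected in this assay. The estimated step is a 1.4-fold lower number from compound 3 to compound 4 (0.14 log units; within the scatter). Compound 4 is expected at 150 nM, with an estimated range of 50 nM to 450 nM.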

Compound 4, half-maximal inhibitory concentration: 165 nM
Compound 4: the middle estimate sits 1.1-fold (0.04 log units) below what was measured, within the range that was stated.
By their numbers in this assay, from the lowest: compound 1; then compounds 2, 4 and 3 (each within the scatter of the next).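

In this assay, 2,4-dichlorophenyl in place of 2-fluorophenyl gives a 1.3-fold lower number from compound 3 to compound 4 (0.10 log units; within the scatter) and, against 3-methylphenyl, a 1.3-fold higher number from compound 2 to compound 4 (0.11 log units; within the scatter) so the three substituted phenyl groups at this position remain within the scatter of one another, now including a chlorinated one. Compound 4 also stays apart from the cyclohexyl compound, with an 8.7-fold higher number from compound 1 to compound 4 (0.94 log units; beyond the scatter) and this gap is beyond the scatter. No evidence is available to explain either result.

Open, as far as these compounds go, is whether the advantage of cyclohexyl extends to cyclopentyl or piperidine. Also open, from the compounds shown here alone, is whether an amine or carboxylic acid on the phenyl ring would shift the number.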